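The source may hold more compounds than are shown below. What is called first, only, known or untested is meant among the compounds shown, and "the series" means these compounds.

Working notes on the series in a functional assay on MCF7 cells (Homo sapiens) for inhibition; a lower number here means a stronger inhibitor, a higher number a weaker inhibitor. Compound 1 `CC(C)C(NC(=O)NO)C(=O)NC1CCCCC1` returns only a limit of the assay, > 100000 nM. Compound 2 `CC(C)C(NC(=O)NO)C(=O)NC1CCCC1` likewise returns a limit, > 100000 nM. Among the compounds with values here, compound 3 `CC(C)C(NC(=O)n1nnc2ccccc21)C(=O)NC1CCCC1` gives 79300 nM in this assay, the one read number so far; the difference between the core of compound 2 and the core of compound 3 is not broken down here. The change cyclohexyl in place of cyclopentyl on an amide-type nitrogen produced a step that the two limits leave unreadable from compound 2 to compound 1, its size hidden by the limit of > 100000 nM in this assay, at which 2 of the 3 values shown sit. Compound 4 `CC(C)C(NC(=O)n1nnc2ccccc21)C(=O)NC1CCCCC1` carries the same change, (cyclohexyl in place of cyclopentyl on an amide-type nitrogen), on the core of compound 3. With the earlier step that the two limits leave unreadable from compound 2 to compound 1 giving no readable size, the step now expected in this assay is a 1.0-fold higher number from compound 3 to compound 4 (0.00 log units; within the scatter), essentially flat. Compound 4 is therefore estimated at 80000 nM in this assay, expected to lie between 30000 nM and 200000 nM.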

Compound 4, half-maximal inhibitory concentration: 79300 nM
Compound 4: middle estimate off by 1.0-fold (0.00 log units), on the high side; the range from low to high includes it.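

In this assay, cyclohexyl in place of cyclopentyl on an amide-type nitrogen gives no change at the digits printed from compound 3 to compound 4 (within the scatter), so the two rings read alike on the core of compound 3. The same change from compound 2 to compound 1 cannot be read, because both compounds return only a limit of the assay: the limit of > 100000 nM in this assay, at which 2 of the 4 values shown sit. Whether the change carries from one core to the other is therefore not shown, as only one readable step exists and a flat step on one core says nothing about the size of the step on the other.

Still open, from the compounds shown here alone, is how a longer chain or an amine on that amide-type nitrogen would read on the core of compound 3.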